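The source may report more compounds than this note shows. Statements on the series, on what has been measured and on what is new or still open speak of the compounds shown alone.

Measured so far:
compound 1, `CCOC(=O)C1=C(Nc2cccc([N+](=O)[O-])c2)S/C(=C\c2ccc[nH]2)C1=O`: 20700 nM
compound 2, `CCOC(=O)C1=C(Nc2ccccc2)S/C(=C\c2ccc(F)c(C#N)c2)C1=O`: 5200 nM

Both were run in a functional assay on MCF7 cells (Homo sapiens) for inhibition; a lower number here means a stronger inhibitor, a higher number a weaker inhibitor. Compound 2 has the lowest number of the two; compound 1 stands higher by a step beyond the scatter. The next compound is compound 3, `CCOC(=O)C1=C(Nc2ccccc2)S/C(=C\C2CCCCC2)C1=O`, which carries cyclohexyl in place of 3-cyano-4-fluorophenyl on a double-bonded chain carbon bound to a double-bonded ring carbon. For the measured compounds named here, no step between measured compounds isolates this kind of change, so the expectation rests on compound 2 alone. In this assay a step of a 2.3-fold higher number from compound 2 to compound 3 (0.36 log units; beyond the scatter) is expected, toward a weaker result, of moderate size and probably beyond the scatter. Compound 3 is estimated at 12000 nM, within 3000 nM to 50000 nM.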

Compound 3, half-maximal inhibitory concentration: 6400 nM
For compound 3 the middle estimate is 1.9-fold (0.27 log units) above the measured one; low and high end bracket the measured number.
By their numbers in this assay, from the lowest: compounds 2 and 3 (each within the scatter of the next); then compound 1.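

In this assay the move to cyclohexyl on the double-bonded chain carbon bound to a double-bonded ring carbon gives a 1.2-fold higher number from compound 2 to compound 3 (0.09 log units; within the scatter) and so leaves the number unchanged within the scatter. On this pair, the position accepts a non-aromatic carbon ring as well as 3-cyano-4-fluorophenyl, and neither the aromatic ring nor the nitrile and fluorine are needed to hold the value. Nothing measured here explains this tolerance.

Still open, going by these compounds, is whether a longer open carbon chain at this position would hold the value. The same question stands for a group carrying an amine or a carboxylic acid.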